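A few compounds are considered here, and "the series" means these few. Any claim that something is new, unique, unknown or untested is made for them only; others in the source may bear on it.

Working notes on the thiazepinone-fused series sharing the core of compound 1, `Cc1ccccc1-n1nc(C)c2c1NC(=O)[C@H](C)S[C@@H]2c1ccc(-c2ccccc2)cc1`. In an assay on isolated protein for agonist activity at Bile acid receptor (Homo sapiens), read by AlphaScreen, with a stated time of 30 min (a lower number here means that less compound is needed, a higher number that more compound is needed for the effect), compound 1 gives 990 nM. Going by the values given here, compound 2, `Cc1ccccc1-n1nc(C)c2c1NC(=O)[C@H](C)S[C@@H]2c1ccc(-c2ccoc2)cc1`, in this assay gives 3500 nM; the one recorded step, a 3.5-fold higher number from compound 1 to compound 2 (0.55 log units; beyond the scatter), shows that replacing the terminal ring on the biphenyl moves the number in the weaker direction. Compound 3, `COC(=O)c1cccc(-c2ccc([C@H]3S[C@@H](C)C(=O)Nc4c3c(C)nn4-c3ccccc3C)cc2)c1`, carries a 3-(methoxycarbonyl)phenyl at that position and in this assay is reported as "not active" (no number reported), so no number stands for it; it sits outside the measured range of compounds 1 and 2.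

Compound 4, `COC(=O)c1ccc(-c2ccc([C@H]3S[C@@H](C)C(=O)Nc4c3c(C)nn4-c3ccccc3C)cc2)cc1`, differs from compound 3 only in the position of the ester on the terminal ring: 4-(methoxycarbonyl)phenyl in place of 3-(methoxycarbonyl)phenyl on an aromatic carbon. Among the compounds with values here, no measured step bears directly on this change; the only step recorded, from compound 1 to compound 2, concerns a different replacement and is of modest size. Given that compound 3 returned no number, compound 4 is expected to be weak as well, and the estimate carries a wide range: 6000 nM, between 1500 nM and 25000 nM, with a real chance that only a limit is reported.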

Compound 4, half-maximal effective concentration: "not active" (no number reported)
The entry for compound 4 holds no number; there is nothing to compare the estimate with.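

Compound 3 and compound 4 both stand without a number, so no step can be read between them, and no evidence bears on this result. The compounds shown leave open whether any methoxycarbonyl-bearing terminal ring can give a number in this assay.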